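Bis-chalcone series: dropping the benzyloxy group on the pendant ring

The source may hold more compounds than are shown below. What is called first, only, known or untested is meant among the compounds shown, and "the series" means these compounds.

Of the compounds shown here, three of the shared core have been tested in an ADME assay on HEK293 cells (Homo sapiens) for cytotoxicity, read by MTT assay, with a stated time of 24 h; a lower number here means a stronger inhibitor, a higher number a weaker inhibitor. Compound 1 `COc1ccc(/C=C/C(=O)c2c(C)cc(O)c(C(=O)/C=C/c3ccc(OC)cc3)c2-c2ccc(OCc3ccccc3)cc2)cc1` gives 28000 nM. Compound 2 `Cc1cc(O)c(C(=O)/C=C/c2ccc(Br)cc2)c(-c2ccc(OCc3ccccc3)cc2)c1C(=O)/C=C/c1ccc(Br)cc1` gives 20000 nM, and compound 3 `Cc1cc(O)c(C(=O)/C=C/c2ccc(OCc3ccccc3)cc2)c(-c2ccc(Br)cc2)c1C(=O)/C=C/c1ccc(OCc2ccccc2)cc1` gives 25000 nM. The lowest number stands with compound 2, but its gaps to compound 3 and to compound 1 both fall within the scatter, so no order among the three can be read from these values. Compound 4 `Cc1cc(O)c(C(=O)/C=C/c2ccc(Br)cc2)c(-c2ccccc2)c1C(=O)/C=C/c1ccc(Br)cc1` has not been measured. It differs from compound 2 by hydrogen in place of benzyloxy on an aromatic carbon. Among the measured compounds shown here, no measured pair shows what this change does in this assay, so the step is expected to stay within the scatter, with no clear direction. The expected step is a 1.3-fold higher number from compound 2 to compound 4 (0.10 log units; within the scatter). Compound 4 is therefore estimated at 25000 nM, with a range from 12000 nM to 55000 nM.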

Compound 4, half-maximal inhibitory concentration: 10000 nM
Estimate against measurement, compound 4: 2.5-fold (0.40 log units) above; the measured number lies below the stated range.
By their numbers in this assay, from the lowest: compounds 4, 2, 3 and 1 (each within the scatter of the next, the first and the last beyond it).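

In this assay, among the compounds shown here, the swap of benzyloxy for hydrogen on an aromatic carbon reads as a 2.0-fold lower number from compound 2 to compound 4 (0.30 log units; within the scatter) and gives the first measured pair at this position. The whole benzyloxy group, aromatic ring included, can therefore leave this place with the step staying within the scatter. Nothing at hand bears on the reason for this step.

A single pair leaves open whether the same swap holds with the other arms of compound 1 and compound 3. Also open, on these data alone, is whether an amine or a carboxylic acid at this place would give a step beyond the scatter.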